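A few compounds are considered here, and "the series" means these few. Any claim that something is new, unique, unknown or untested is made for them only; others in the source may bear on it.

Compound 1 `CN(C)C(=S)N/N=C/c1ccc2ccccc2n1` gives 90 nM
Compound 2 `S=C(N/N=C/c1ccc2ccccc2n1)Nc1cccc(Br)c1` gives 70000 nM
Compound 3 `NC(=S)N/N=C/c1nc2ccccc2s1` gives 5350 nM

All three values come from a functional assay on HeLa cells (Homo sapiens) for antiproliferative activity, read by sulforhodamine B assay, with a stated time of 72 h (a higher number here means a weaker inhibitor, a lower number a stronger inhibitor), and span a wide range. Compound 2 has the highest number of the three, beyond the scatter from both compound 3 and compound 1, which makes it the weakest inhibitor here. Compound 4 `S=C(N/N=C/c1ccc2ccccc2n1)Nc1ccccc1Br` carries 2-bromophenyl in place of 3-bromophenyl on an amide-type nitrogen. Among the compounds with values here, no measured pair isolates such a change, so the direction is a judgement: a modest move toward a lower number is expected, possibly none beyond the scatter. Compound 2 at 70000 nM is the only anchor for this. The expected change is a 2.8-fold lower number from compound 2 to compound 4 (0.45 log units; beyond the scatter) and remains tentative. For compound 4 the estimated value is 25000 nM (expected range 3000 nM to 100000 nM).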

Compound 4, half-maximal inhibitory concentration: > 100000 nM
Compound 4: no number, only a limit; the forecaster's own chance of this, stated with the estimate: 15%; middle value at least 4.0-fold (0.60 log units) from the limit.
By their numbers in this assay, from the lowest: compound 1; then compound 3; then compound 2. At a limit, above all of these: compound 4.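

In this assay compound 4 gives no number, only a limit: the limit of > 100000 nM in this assay, at which 1 of the 4 values shown sits.

Exchanging 3-bromophenyl for 2-bromophenyl on the amide-type nitrogen gives an at least 1.4-fold higher number from compound 2 to compound 4 (0.15 log units; that floor lies within the scatter), so this change brings no gain in potency, while the true size of any loss stays unresolved. This is the first pair in the series that isolates a change at this position, and neither bromophenyl placement shown gives a measured value below that of compound 2.

Still open, going by these compounds, is how a plain phenyl group, without bromine, or a morpholine on this nitrogen would read in this assay.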